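Nitro Group Added Where No Step Has Yet Gone

A few compounds are considered here, and "the series" means these few. Any claim that something is new, unique, unknown or untested is made for them only; others in the source may bear on it.

Of the compounds shown here, three built on the same core have been measured in an ADME assay. Compound 1 `O=S(=O)(Nc1ccccc1)c1ccccc1` gives 9.1. Compound 2 `O=S(=O)(Nc1ccc(Cl)cc1)c1ccccc1` gives 8.75, and compound 3 `Cc1ccc(NS(=O)(=O)c2ccccc2)cc1` gives 9.34. Compound 2 stands lowest of the three numbers: the step from compound 2 to compound 3 is a number 0.59 log units higher from compound 2 to compound 3 (beyond the scatter), and the step from compound 1 to compound 3 is a number 0.24 log units higher from compound 1 to compound 3 (within the scatter), so compound 1 and compound 3 cannot be told apart.

Compound 4 `O=[N+]([O-])c1ccc(S(=O)(=O)Nc2ccc(Cl)cc2)cc1` differs from compound 2 in a single place: nitro in place of hydrogen on an aromatic carbon. Going by the values given here, no measured step covers this change. Among the compounds with values here, every step so far alters the ring that carries the sulfonamide nitrogen, whereas this change sits on the ring attached to the sulfonyl group, and no measured compound carries a nitro group anywhere. Within the data shown here, the only measured step that lowered the number, from compound 1 to compound 2, was a number 0.35 log units lower from compound 1 to compound 2 (beyond the scatter), a modest move for a chloro group. A nitro group is a larger addition, and the expectation is a clearly larger drop, a number 0.85 log units lower from compound 2 to compound 4 (beyond the scatter), though with wide uncertainty. Compound 4 is therefore expected to give 7.9 in this assay, somewhere between 7.4 and 8.5.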

Compound 4, acid dissociation constant: 6.24
The estimate for compound 4 lay 1.66 log units above the measured number, and the stated range ends above it.
By their numbers in this assay, from the lowest: compound 4; then compound 2; then compounds 1 and 3 (each within the scatter of the next).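

In this assay, going by these compounds alone, nitro in place of hydrogen on an aromatic carbon, para to a large group, gives a number 2.51 log units lower from compound 2 to compound 4 (beyond the scatter) and so shows that a single change at this position, which no earlier step touched, can shift the number by a large amount. Among the earlier steps, a number 0.35 log units lower from compound 1 to compound 2 (beyond the scatter) and a number 0.59 log units higher from compound 2 to compound 3 (beyond the scatter) are both only modest, so those compounds gave no sign that a one-place change on this core could reach such a size. Nothing available here gives a measured reason for the size of the new step.

The compounds shown carry only nitro at this position, so they leave open how far the number would move with an amine, a carboxylic acid or a nitrile in the same place, and whether any of these would shift it in the same direction. They also leave open whether nitro would give a step of similar size on compound 1, where the chloro group of compound 2 is absent, or on compound 3, which carries methyl there instead.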